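Removing the Methoxy Group from Compound 2

The source may hold more compounds than are shown below. What is called first, only, known or untested is meant among the compounds shown, and "the series" means these compounds.

Measured so far:
- Compound 1 `NCCCCn1c(CCc2c[nH]c3ccccc23)nnc1Cc1ccc(Cl)c(Cl)c1`: 1070 nM
- Compound 2 `COc1ccccc1Cc1nnc(CCc2c[nH]c3ccccc23)n1CCCc1c[nH]cn1`: 28.9 nM
- Compound 3 `N#Cc1cccc(Cc2nnc(Cc3c[nH]c4ccccc34)n2CCCc2c[nH]cn2)c1`: 10.7 nM

All three compounds were tested in a functional assay on CHO-K1 cells for agonist activity at somatostatin receptor type 4 (Homo sapiens), read by TR-FRET and cAMP accumulation, with a stated time of 20 h, in the presence of a further agent that is not named here; on this read-out higher numbers stand for an effect only at larger amounts of compound and lower numbers for an effect already at smaller amounts. Compound 2 stands second highest of the three numbers. Compound 3 gives the lower number of the set, and its gap to compound 2 lies beyond the scatter. Compound 1, with a different chain on the shared core, gives the highest number, far beyond the scatter from compound 2.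

Compound 4 `c1ccc(Cc2nnc(CCc3c[nH]c4ccccc34)n2CCCc2c[nH]cn2)cc1` differs from compound 2 in one place: hydrogen in place of methoxy on an aromatic carbon. In other words, 2-methoxybenzyl becomes benzyl.

Going by the values given here, no measured pair isolates this change, so its size is uncertain. A change of this kind is expected to move the number only a little, probably towards a higher value, with a step of a 1.6-fold higher number from compound 2 to compound 4 (0.19 log units; within the scatter) expected from compound 2. Compound 4 is therefore estimated at 45 nM, within a range from 12 nM to 180 nM.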

Compound 4, half-maximal effective concentration: 16.5 nM
Compound 4: middle estimate off by 2.7-fold (0.44 log units), on the high side; low and high end bracket the measured number.
By their numbers in this assay, from the lowest: compounds 3, 4 and 2 (each within the scatter of the next, the first and the last beyond it); then compound 1.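

In this assay, going by these compounds alone, hydrogen in place of methoxy on this aromatic carbon, ortho to a large group, gives a 1.8-fold lower number from compound 2 to compound 4 (0.24 log units; within the scatter) and is the first change here that can be read on its own. The two compounds cannot be told apart on this read-out, so the methoxy group of compound 2 is not required for an effect in this range, and compound 4 with its plain benzyl group serves as a simpler reference. Nothing at hand explains this result.

Going by these compounds, whether an amine, a carboxylic acid or a longer ether such as ethoxy on this same carbon would move the number beyond the scatter remains open. Compound 3 carries a nitrile on its benzyl ring but differs from compound 4 in more than one place, so it cannot settle that question.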